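This account rests on a few compounds, and the source may have more. Where it says the series, first, only, none or still open, it means among the compounds named here.

Measured in an ADME assay on BJ cells (Homo sapiens), read by MTT assay, with a stated time of 72 h; a higher number here means a weaker inhibitor, a lower number a stronger inhibitor:
compound 1 `CNc1ncnc2c1c(-c1ccsc1)cn2[C@@H]1O[C@H](CO)[C@@H](O)[C@H]1O`: > 100000 nM (a limit)
compound 2 `C#Cc1cn([C@@H]2O[C@H](CO)[C@@H](O)[C@H]2O)c2ncnc(NC)c12`: 86000 nM

Among the measured compounds shown here, compound 2 holds the only actual number, since the other value is a limit (the limit of > 100000 nM in this assay, at which 1 of the 2 values shown sits). Compound 3 `CNc1ncnc2c1c(I)cn2[C@@H]1O[C@H](CO)[C@@H](O)[C@H]1O` carries iodo in place of ethynyl on an aromatic carbon. For the measured compounds named here, the one measured step bearing on this, also a replacement on an aromatic carbon, is an at least 1.1-fold lower number from compound 1 to compound 2 (0.06 log units; that floor lies within the scatter), so no measured change beyond the scatter exists. The expected step in this assay is therefore none beyond the scatter, at a 1.1-fold lower number from compound 2 to compound 3 (0.03 log units; within the scatter). For compound 3 the estimated value is 80000 nM, with an expected range of 35000 nM to 100000 nM.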

Compound 3, half-maximal inhibitory concentration: > 100000 nM
Compound 3: a limit, no number; the forecaster's own chance of this, stated with the estimate: 40%; middle value at least 1.2-fold (0.09 log units) from the limit.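

In this assay, iodo in place of ethynyl on this aromatic carbon gives an at least 1.1-fold higher number from compound 2 to compound 3 (0.06 log units; that floor lies within the scatter), so no difference beyond the scatter can be claimed for this change. The value of compound 3 is a limit, and the step between the iodo and thiophen-3-yl groups cannot be read, since both values are limits. A small single-atom group thus joins a ring at the same limit, with only ethynyl giving an actual number: the limit of > 100000 nM in this assay, at which 2 of the 3 values shown sit.

On these data alone, whether an amine, a carboxylic acid or a longer chain on this carbon would give a clearly lower number remains open. As far as these compounds go, the true values of compound 1 and compound 3 also remain open.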